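From Bromo to Vinyl: Estimating Compound 4

This account rests on a few compounds, and the source may have more. Where it says the series, first, only, none or still open, it means among the compounds named here.

Compound 1 `Cc1nc(C#Cc2cc(F)cc(F)c2)cs1`: 25.3 nM
Compound 2 `Cc1nc(C#Cc2cncc(Br)c2)cs1`: 60 nM
Compound 3 `Cc1nc(C#Cc2ccc3[nH]ccc3c2)cs1`: > 10000 nM (a limit, not a number)

In a functional assay on CHO cells for agonist activity at metabotropic glutamate receptor 5 (Homo sapiens), read by inositol phosphate accumulation (on this read-out lower numbers stand for stronger inhibition and higher numbers for weaker inhibition), compound 2 gives 60 nM, the higher of the two numbers, while compound 1 gives 25.3 nM, lower by more than the usual scatter. For compound 3 the read-out is only (the limit of > 10000 nM in this assay, at which 1 of the 3 values shown sits).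

Compound 4 `C=Cc1cncc(C#Cc2csc(C)n2)c1` differs from compound 2 by vinyl in place of bromo on an aromatic carbon. Going by the values given here, no measured pair shows what this swap does. The change is expected to be small: the step of no change at the digits printed from compound 2 to compound 4 (within the scatter) is estimated to lie within the scatter, in no clear direction. Compound 4 is therefore expected at 60 nM, most likely between 20 nM and 200 nM.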

Compound 4, half-maximal inhibitory concentration: 2.01 nM
Compound 4: the middle estimate sits 30-fold (1.47 log units) above what was measured; the whole stated range lies above it.
By their numbers in this assay, from the lowest: compound 4; then compound 1; then compound 2. At a limit, above all of these: compound 3.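

In this assay, vinyl in place of bromo on this aromatic carbon, two atoms from the ring nitrogen, gives a 30-fold lower number from compound 2 to compound 4 (1.47 log units; beyond the scatter). Going by these compounds alone, this is the first step seen between two measured compounds, and it shows that the read-out responds strongly to the group at this position. Nothing measured here accounts for the size of the step. Only bromo and vinyl are seen at this position. On these data alone, whether the double bond matters remains open, as an ethyl group would show, and so does the effect of an amine or a methoxy group.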